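This account rests on a few compounds, and the source may have more. Where it says the series, first, only, none or still open, it means among the compounds named here.

Of the compounds shown here, two of one shared core have been measured so far. Compound 1 `CC(C)=CCOc1c(C)c(C)c2c(c1C)CCC(C)(COc1ccc(/C=C3\SC(=O)NC3=O)cc1C)O2` carries a 2-methylprop-1-en-1-yl group on a saturated chain carbon bound to an oxygen on an aromatic ring, and in a functional assay on MCF7 cells (Homo sapiens), tested at 2.5 uM (a lower number here means a stronger effect, a higher number a weaker effect of the compound at the concentration tested), compound 1 gives 89%. Compound 2 `C=CCOc1c(C)c(C)c2c(c1C)CCC(C)(COc1ccc(/C=C3\SC(=O)NC3=O)cc1C)O2` carries a vinyl group at that place instead, and in this assay compound 2 gives 84%. Among the measured compounds shown here, the only step recorded between them, a number 5 percentage points lower from compound 1 to compound 2 (within the scatter), lies within the scatter, so the two numbers cannot be told apart. Compound 1 has the higher of the two numbers shown, with compound 2 as its nearest neighbour, a difference that is within the scatter.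

The next compound, compound 3 `CC(C)=CCOc1c(C)c(C)c2c(c1C)CCC(C)(COc1ccc(/C=C3\SC(=O)NC3=O)cc1Br)O2`, differs from compound 1 in a single place: bromo in place of methyl on an aromatic carbon. For the measured compounds named here, no measured step bears on this exchange, since the one step recorded concerns a different group on a different part of the core. Without any such guidance, no change beyond the scatter is expected in this assay from compound 1 to compound 3, and the expected step is a number 3 percentage points lower from compound 1 to compound 3 (within the scatter). Compound 3 is therefore estimated at 86%, within a range from 72% to 98%.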

Compound 3, a percentage reported as activity, at one concentration (the size of the read-out at that concentration, not a potency): 96%
The estimate for compound 3 lay 10 percentage points below the measured number, within the range that was stated.
By their numbers in this assay, from the lowest: compounds 2, 1 and 3 (each within the scatter of the next, the first and the last beyond it).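

Among the compounds shown here, the result gives the first reading at the aromatic carbon ortho to a large group, where the earlier compounds carried only methyl. In this assay, bromo in place of methyl gives a number 7 percentage points higher from compound 1 to compound 3 (within the scatter) and so the two numbers cannot be told apart at the one concentration tested. The exchange of one heavy atom for another, with no hydrogen-bond donors or acceptors entering or leaving, therefore shows no effect beyond the scatter at this position, and no measurement is available that could explain the small difference seen.

The compounds shown leave open whether another group on this aromatic carbon, such as a methoxy group, an amine or a carboxylic acid, would shift the number in this assay beyond the scatter. They also leave open whether bromo would give a similar reading when paired with the vinyl group of compound 2 or with a longer chain in its place, since bromo is shown here only with the 2-methylprop-1-en-1-yl group of compound 1.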